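The source may hold more compounds than are shown below. What is called first, only, known or untested is meant among the compounds shown, and "the series" means these compounds.

Of the compounds shown here, three have been measured in an in vitro ADME assay on microsomes from liver (Homo sapiens) for pharmacokinetics, read by LC-MS, with a stated time of 10 min, tested at 1 uM (a higher number here means faster removal of the compound, a lower number slower removal), so far.

- compound 1 `CN1C[C@H](C(=O)Nc2cccc(F)c2)[C@@H](c2ccc(/C=C/C(=O)Nc3ccccc3N)cc2)C1` gives 6 mL/min/kg
- compound 2 `CC(C)(CO)N1C[C@H](C(=O)Nc2ccc(Cl)cc2)[C@@H](c2ccc(/C=C/C(=O)Nc3ccccc3N)cc2)C1` gives 12 mL/min/kg
- compound 3 `CCNC(=O)N1C[C@H](C(=O)Nc2ccc(Cl)cc2)[C@@H](c2ccc(/C=C/C(=O)Nc3ccccc3N)cc2)C1` gives 9 mL/min/kg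

Compound 3 at 9 mL/min/kg stands within the scatter of both compound 2 and compound 1, so no order can be drawn around it. Compound 4 `Nc1ccccc1NC(=O)/C=C/c1ccc([C@H]2CN(C3CCOCC3)C[C@@H]2C(=O)Nc2ccc(Cl)cc2)cc1` is still unmeasured and carries oxan-4-yl in place of ethylcarbamoyl on an amine nitrogen in a ring, with oxan-4-yl in place of ethylcarbamoyl on an amine nitrogen in a ring as the counted difference. Going by the values given here, the one measured step at that nitrogen is a 1.3-fold lower number from compound 2 to compound 3 (0.12 log units; within the scatter) and, with compound 3 as the starting point, no change beyond the scatter is therefore expected in this assay in either direction. Oxan-4-yl itself has not been measured there, so this rests on a single small step. The expected step is a 1.1-fold higher number from compound 3 to compound 4 (0.05 log units; within the scatter) and it remains an estimate. For compound 4 the estimated clearance is 10 mL/min/kg with an expected range from 5 mL/min/kg to 20 mL/min/kg until the measurement is in.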

Compound 4, clearance: 12 mL/min/kg
Compound 4: the middle estimate sits 1.2-fold (0.08 log units) below what was measured; measured number inside the range.
By their numbers in this assay, from the lowest: compounds 1, 3, 2 and 4 (each within the scatter of the next).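

With compound 4, a six-membered non-aromatic ring now sits on the amine nitrogen in a ring, and in this assay replacing ethylcarbamoyl with oxan-4-yl gives a 1.3-fold higher number from compound 3 to compound 4 (0.12 log units; within the scatter). Replacing the open-chain 1-(hydroxymethyl)-1-methylethyl with oxan-4-yl gives no change at the digits printed from compound 2 to compound 4 (within the scatter). Compounds 2, 3 and 4, which differ only in this group, therefore all lie within the scatter of one another, so this position has not yet shown any clear effect of the group it carries.

From the compounds shown here alone, whether a carboxylic acid, a primary amine or a longer chain on this nitrogen would produce a step beyond the scatter remains open. No measurement shown speaks to the reason these numbers stay so close.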